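Swapping 3,4-dihydroxyphenyl for cyclohexyl in compound 3

A few compounds are considered here, and "the series" means these few. Any claim that something is new, unique, unknown or untested is made for them only; others in the source may bear on it.

For the measured compounds named here, compound 2 `C/C=C1/[C@H](O[C@@H]2O[C@H](CO)[C@@H](O)[C@H](O)[C@H]2O)OC=C(C(=O)OC)[C@H]1CC(=O)OCCc1ccc(O)c(O)c1` stands at the higher of the two numbers measured so far in a functional assay on B16-F1 cells (Mus musculus) for antiproliferative activity, read by MTT assay, with a stated time of 72 h (on this read-out higher numbers stand for weaker inhibition and lower numbers for stronger inhibition), giving 284000 nM. Going by the values given here, its only neighbour, compound 1 `C/C=C1/[C@H](O[C@@H]2O[C@H](COC(C)=O)[C@@H](OC(C)=O)[C@H](OC(C)=O)[C@H]2OC(C)=O)OC=C(C(=O)OC)[C@H]1CC(=O)OCCC`, gives 44000 nM in this assay, a gap that lies beyond the usual scatter. Compound 3 `C/C=C1/[C@H](O[C@@H]2O[C@H](CO)[C@@H](O)[C@H](O)[C@H]2O)OC=C(C(=O)OC)[C@H]1CC(=O)OCCC1CCCCC1` differs from compound 2 in one place: cyclohexyl in place of 3,4-dihydroxyphenyl on a saturated chain carbon, two bonds along the chain from an oxygen next to a carbonyl group. Among the compounds with values here, no measured pair shows this exact change, so its size is open. A modest move toward stronger inhibition is expected, a 1.9-fold lower number from compound 2 to compound 3 (0.28 log units; within the scatter), though a step within the scatter cannot be excluded. Compound 3 is therefore estimated at 150000 nM in this assay, within 50000 nM to 400000 nM.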

Compound 3, half-maximal inhibitory concentration: 5040 nM
Estimate against measurement, compound 3: 30-fold (1.47 log units) above; the whole stated range lies above it.
By their numbers in this assay, from the lowest: compound 3; then compound 1; then compound 2.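

In this assay, the saturated chain carbon, two bonds along the chain from an oxygen next to a carbonyl group, proves highly sensitive to the ring it carries: cyclohexyl in place of 3,4-dihydroxyphenyl gives a 56-fold lower number from compound 2 to compound 3 (1.75 log units; beyond the scatter). For the compounds shown here, the earlier compounds offered no pair differing here alone, so this is the first reading of this change. Nothing available accounts for the size of the step.

The change replaces the aromatic ring and removes both hydroxyl groups at once, leaving open which of the two matters. A plain phenyl group on the same chain would separate them.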